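This account rests on a few compounds, and the source may have more. Where it says the series, first, only, none or still open, it means among the compounds named here.

Measured so far in a functional assay (Pituitary gland cell) with Rattus norvegicus as the target; on this read-out lower numbers stand for an effect already at smaller amounts and higher numbers for an effect only at larger amounts of compound:
Compound 1 `CC(C)(O)CNC(C)(C)CC(=O)N[C@@H]1CCc2ccccc2N(Cc2ccc(-c3ccccc3-c3nn[nH]n3)cc2)C1=O` gives 10 nM.
Compound 2 `CC(C)(CC(=O)N[C@@H]1CCc2ccccc2N(Cc2ccc(-c3ccccc3-c3nn[nH]n3)cc2)C1=O)NC[C@H](O)CO` gives 10 nM.
Compound 3 `CC(C)(N)C(=O)N[C@@H]1CCc2ccccc2N(Cc2ccc(-c3ccccc3-c3nn[nH]n3)cc2)C1=O` gives 30 nM.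

Compound 1 stands level with compound 2, the two lowest numbers: the step of no change at the digits printed from compound 1 to compound 2 (within the scatter) is within the scatter, while compound 3 lies apart by a 3.0-fold higher number from compound 1 to compound 3 (0.48 log units; beyond the scatter). Compound 4 `C[C@@H](O)CCNC(C)(C)C(=O)N[C@@H]1CCc2ccccc2N(Cc2ccc(-c3ccccc3-c3nn[nH]n3)cc2)C1=O` differs from compound 1 in one place: 1-((3-hydroxybutyl)amino)-1-methylethyl in place of 2-((2-hydroxy-2-methylpropyl)amino)-2-methylpropyl on a carbonyl carbon. The entering group keeps an amine nitrogen carrying a hydroxyalkyl chain, as compound 1 and compound 2 do, but it is a 1-methylethyl on the carbonyl carbon, as the 1-amino-1-methylethyl of compound 3 is. Among the measured compounds shown here, the steps that bear on this are a 3.0-fold higher number from compound 1 to compound 3 (0.48 log units; beyond the scatter) and a 3.0-fold higher number from compound 2 to compound 3 (0.48 log units; beyond the scatter), both modest rises. A smaller rise is therefore expected, a 2.0-fold higher number from compound 1 to compound 4 (0.30 log units; within the scatter), within the scatter. Compound 4 is estimated at 20 nM, with a range from 7 nM to 50 nM.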

Compound 4, concentration for half-maximal effect: 100 nM
The estimate for compound 4 lay 5.0-fold (0.70 log units) below the measured number, outside the stated range (above it).
By their numbers in this assay, from the lowest: compounds 1 and 2 (each within the scatter of the next); then compound 3; then compound 4.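

Putting 3-hydroxybutyl in place of hydrogen on the amine nitrogen gives a 3.3-fold higher number from compound 3 to compound 4 (0.52 log units; beyond the scatter), so a hydroxyalkyl chain on that nitrogen does not by itself lower the number at this position. Replacing the 2-methylpropyl-based groups with 1-((3-hydroxybutyl)amino)-1-methylethyl on the carbonyl carbon gives a 10-fold higher number from compound 1 to compound 4 (1.00 log units; beyond the scatter) and a 10-fold higher number from compound 2 to compound 4 (1.00 log units; beyond the scatter), a larger rise than compound 3 had suggested.

Still open, on these data alone, is whether a 2-hydroxyethyl chain on the same amine nitrogen would avoid this rise. No measured evidence here accounts for these steps.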